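Swapping the aryl group on the thiazole of a fatty acid receptor agonist

This account rests on a few compounds, and the source may have more. Where it says the series, first, only, none or still open, it means among the compounds named here.

Of the compounds shown here, three sharing one core have been measured in a functional assay on CHO cells for agonist activity at Free fatty acid receptor 1 (Homo sapiens), read by FLIPR and calcium flux, tested at 100 nM; a higher number here means a stronger effect of the compound at the concentration tested, a lower number a weaker effect. Compound 1 `Cc1nc(-c2cc3ccccc3o2)sc1COc1ccc2c(c1)OCC2CC(=O)O` gives 14.8%, compound 2 `Cc1ccccc1-c1nc(C)c(COc2ccc3c(c2)OCC3CC(=O)O)s1` gives 10.7%, and compound 3 `Cc1cccc(-c2nc(C)c(COc3ccc4c(c3)OCC4CC(=O)O)s2)c1` gives 47.2%, the highest of the three, standing a number 32.4 percentage points higher from compound 1 to compound 3 (beyond the scatter) and a number 36.5 percentage points higher from compound 2 to compound 3 (beyond the scatter). The step from compound 1 to compound 2 was a number 4.1 percentage points lower from compound 1 to compound 2 (within the scatter).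

Compound 4 `Cc1nc(-c2ccccc2Cl)sc1COc1ccc2c(c1)OCC2CC(=O)O` is not yet measured; it differs from compound 3 by 2-chlorophenyl in place of 3-methylphenyl on an aromatic carbon. The entering 2-chlorophenyl follows the pattern of the 2-methylphenyl of compound 2 more closely than the 3-methylphenyl of compound 3, and the step of a number 36.5 percentage points higher from compound 2 to compound 3 (beyond the scatter) shows how much that pattern mattered. A large drop in this assay is therefore expected, back toward the level of compound 2, giving an estimated a number 32.2 percentage points lower from compound 3 to compound 4 (beyond the scatter). Compound 4 is expected to show about 15%, within a range from 4% to 35%.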

Compound 4, a percentage reported as activity, at one concentration (the size of the read-out at that concentration, not a potency): 12.4%
Beside the measured number, compound 4's estimate is 2.6 percentage points above it; the range from low to high includes it.
By their numbers in this assay, from the lowest: compounds 2, 4 and 1 (each within the scatter of the next); then compound 3.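

In this assay, 2-chlorophenyl in place of 3-methylphenyl on this aromatic carbon costs almost all of the higher reading of compound 3 (a number 34.8 percentage points lower from compound 3 to compound 4 (beyond the scatter)). Chloro in place of methyl on the same phenyl carbon changes little (a number 1.7 percentage points higher from compound 2 to compound 4 (within the scatter)), so the low reading of compound 2 is not confined to its methyl group. For the compounds shown here, the 1-benzofuran-2-yl group gives a similar result (a number 2.4 percentage points lower from compound 1 to compound 4 (within the scatter)), which leaves compound 3, with its 3-methylphenyl, as the only one of these four compounds that stands apart.

No measurement shown here explains these differences. Open questions are whether a 3-chlorophenyl group would reach the level of compound 3, which would separate the place of the group from its identity, and how a plain phenyl group would compare.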